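This account rests on a few compounds, and the source may have more. Where it says the series, first, only, none or still open, it means among the compounds named here.

Of the compounds shown here, three from this series have been tested in an ADME assay on BJ cells (Homo sapiens) for cytotoxicity, with a stated time of 72 h (on this read-out higher numbers stand for an effect only at larger amounts of compound and lower numbers for an effect already at smaller amounts), and none of them produced a number. Compound 1, `O=C(Nc1cc(-c2nc3ccccc3s2)ccc1Cl)c1cc([N+](=O)[O-])ccc1Cl`, gave only the assay limit of > 25000 nM in this assay. Compound 2, `O=C(Nc1ccc(Cl)c(-c2nc3ccccc3s2)c1)c1cc([N+](=O)[O-])ccc1Cl`, likewise reached only the limit of > 25000 nM in this assay. Compound 3, `O=C(Nc1nc2c(Cl)cccc2s1)c1cc([N+](=O)[O-])ccc1Cl`, which carries its amide on a different core, also stopped at the limit of > 27000 nM in this assay. So compound 1 stands where every measured compound stands: at a limit, with no measured number to set it apart from compound 2 or compound 3, because the limit of > 25000 nM in this assay, at which 2 of the 3 values shown sit, and the limit of > 27000 nM in this assay, at which 1 of the 3 values shown sits, together account for all three values shown.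

Compound 4, `Cc1ccc(-c2nc3ccccc3s2)cc1NC(=O)c1cc([N+](=O)[O-])ccc1Cl`, has not yet been measured. It differs from compound 1 in one place: methyl in place of chloro on an aromatic carbon. For the measured compounds named here, no step between measured compounds is available to show what such a change does here, and the three measured values are all limits, so there is nothing to suggest a move away from them. The expected step that the limit leaves unreadable from compound 1 to compound 4 in this assay is none beyond the scatter. Compound 4 is therefore expected to give about 30000 nM in this assay, most likely again as a limit, within a range from 15000 nM to 100000 nM.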

Compound 4, half-maximal effective concentration: > 14000 nM
Compound 4 gave a limit, no number (the forecaster's own chance of this, stated with the estimate: 85%); the middle value does not contradict the limit.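

Compound 1 and compound 4 both stopped at a limit in this assay, so no step can be read for methyl in place of chloro. The compounds shown leave open at what concentration any of them would produce a measured effect, and whether this change alters that concentration at all.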